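Methyl on an aromatic carbon across two pairs

The compounds below may be only part of what the source reports. "The series", "measured", "known", "first", "only" and "open" are said of these compounds alone.

Compound 3 `CCOc1ccc(Cl)cc1C(C)NC(=O)NS(=O)(=O)c1ccccc1` has a phenyl where compound 1 `CCOc1ccc(Cl)cc1C(C)NC(=O)NS(=O)(=O)c1ccc(C)cc1` has a 4-methylphenyl. In a functional assay on thoracic aorta (Rattus norvegicus, strain Wistar), with a stated time of 15 min (a higher number here means that more compound is needed for the effect, a lower number that less compound is needed), compound 3 gives only a limit, > 300000 nM. In this assay compound 1 likewise gives only a limit, > 300000 nM. The step that the two limits leave unreadable from compound 3 to compound 1 therefore cannot be read because of the limit of > 300000 nM in this assay, at which 2 of the 3 values shown sit. The change itself is methyl in place of hydrogen on an aromatic carbon.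

Compound 2 `CC(NC(=O)N(C)S(=O)(=O)c1ccc(Cl)cc1)c1ccccc1OCc1ccccc1` rests on a different core; the difference between the core of compound 2 and the core of compound 3 is not broken down here. In this assay, among the measured compounds shown here, compound 2 gives 38400 nM, the only number among the three measured compounds. Compound 4 `Cc1ccc(OCc2ccccc2)c(C(C)NC(=O)N(C)S(=O)(=O)c2ccc(Cl)cc2)c1` is the compound still to be measured, derived from compound 2 by methyl in place of hydrogen on an aromatic carbon. This is the same kind of change as that from compound 3 to compound 1, but not the same: in the measured pair the methyl enters para to a large group, whereas in compound 4 it enters meta to a large group and para to a benzyloxy group.

The measured pair gives no readable size for this kind of step. For the measured compounds named here, for the step from compound 2 to compound 4 a change within the usual scatter is expected, a 1.1-fold lower number from compound 2 to compound 4 (0.04 log units; within the scatter), since the only anchor is compound 2 at 38400 nM. In this assay compound 4 is expected at 35000 nM, with an estimated range from 12000 nM to 110000 nM.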

Compound 4, half-maximal effective concentration: 142000 nM
Beside the measured number, compound 4's estimate is 4.1-fold (0.61 log units) below it; the whole stated range lies below it.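

In this assay, methyl in place of hydrogen on an aromatic carbon gives a 3.7-fold higher number from compound 2 to compound 4 (0.57 log units; beyond the scatter), a step beyond the usual scatter, so on the core of compound 2 this small change, meta to a large group and para to a benzyloxy group, does move the number upward. Among the compounds shown here, this is a single readable step on a single core, and it does not show that the change would have the same size or direction on another core, or at another place on the ring, since the methyl in compound 1 stands in a different setting from the one in compound 4. No comparison of the two cores is possible for this change, because the step from compound 3 to compound 1 cannot be read, with both of its values being limits: the limit of > 300000 nM in this assay, at which 2 of the 4 values shown sit.

Going by these compounds, whether the higher number belongs to methyl in particular remains open, since a methoxy group or an amine on the same aromatic carbon of the core of compound 2 would show whether other groups there move the number in the same way. Also open, on these data alone, is whether a carboxylic acid in place of the benzyloxy group would leave a readable number on that core, with or without the methyl.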